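Carbamate in place of amide on a shared pyrazole series

The source may report more compounds than this note shows. Statements on the series, on what has been measured and on what is new or still open speak of the compounds shown alone.

Measured compounds:
compound 1, `Cc1cc(C(=O)O)nn1C(C)c1cc(Cl)ccc1OCc1ccccc1`, 1
compound 2, `Cc1cc(C(=O)NCc2ccccn2)nn1Cc1cc(Cl)ccc1OCc1ccccc1`, > 3.7
compound 3, `Cc1cc(C(N)=O)nn1Cc1cc(Cl)ccc1OCC(C)C`, 3.1

Of the compounds shown here, three built on the same core have been measured in a physicochemical assay for lipophilicity, at pH 7.4; a higher number here means a more lipophilic compound, a lower number a more polar compound. Compound 1 gives 1. Compound 3 gives 3.1. For compound 2 only a limit is known: in this assay compound 2 gives > 3.7, which is a limit of the assay and not a number, so compound 2 stands at the upper edge of what has been measured here, as noted in the limit of > 3.7 in this assay, at which 1 of the 3 values shown sits. No pair of these compounds differs in only one place, so no measured step can be drawn among them.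

Compound 4, `Cc1cc(NC(=O)OCc2ccccn2)nn1Cc1cc(Cl)ccc1OCc1ccccc1`, has not yet been measured in this assay. It differs from compound 2 as follows: (((pyridin-2-yl)methoxy)carbonyl)amino in place of ((pyridin-2-yl)methyl)carbamoyl on an aromatic carbon. Among the compounds with values here, with no measured step of this kind, the account expects a change from compound 2 to compound 4 of a step that the limit leaves unreadable from compound 2 to compound 4, that is, nothing beyond the scatter. Compound 4 is therefore estimated at 4, between 3.4 and 4.6, and is expected most likely to return a limit again.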

Compound 4, distribution coefficient: 3.1
The estimate for compound 4 lay 0.90 log units above the measured number; measured number below the stated range.
By their numbers in this assay, from the lowest: compound 1; then compounds 3 and 4 (each within the scatter of the next). At a limit, above all of these: compound 2.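

In this assay, within the data shown here, putting (((pyridin-2-yl)methoxy)carbonyl)amino in place of ((pyridin-2-yl)methyl)carbamoyl on this aromatic carbon gives a number at least 0.60 log units lower from compound 2 to compound 4 (beyond the scatter), the only step that can be read. The number at this place therefore responds to the link that joins the pyridin-2-yl group to the core, even though the leaving and entering groups hold the same aromatic ring and the same count of hydrogen-bond donors. The full size of the step cannot be read, because compound 2 stands at a limit and not at a number: the limit of > 3.7 in this assay, at which 1 of the 4 values shown sits.

This single step does not separate the added oxygen from the change in the atom attached to the core. From the compounds shown here alone, how a urea or a simple amine would read at this place in this assay stays open, as does whether a phenyl group in place of the pyridin-2-yl would give a step of similar size.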